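A few compounds are considered here, and "the series" means these few. Any claim that something is new, unique, unknown or untested is made for them only; others in the source may bear on it.

In a functional assay on MCF7 cells (Homo sapiens) for cytotoxicity, read by MTT assay, with a stated time of 24 h (on this read-out higher numbers stand for weaker inhibition and lower numbers for stronger inhibition), compound 1 (`COc1ccc2c(c1)cc(-c1cc(OC)c(OC)c(OC)c1)n2Cc1ccc(OCc2ccccc2)cc1`) gives > 30000 nM, which is a limit of the assay and not a number. Compound 2 (`COc1ccc2c(c1)c(Cc1ccc(OCc3ccccc3)cc1)c(-c1cc(OC)c(OC)c(OC)c1)n2Cc1ccc(OCc2ccccc2)cc1`) gives > 30000 nM, which is also a limit. Compound 1 therefore has no numerical value to start from, and the data so far amount to the limit of > 30000 nM in this assay, at which 2 of the 2 values shown sit.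

Compound 3 (`COc1ccc2c(c1)cc(-c1cc(OC)c(OC)c(OC)c1)n2Cc1ccc(OC(C)CN(C)C)cc1`) keeps the core of compound 1 but carries 1-((dimethylamino)methyl)ethyl in place of benzyl on an oxygen on an aromatic ring. Among the measured compounds shown here, no measured step covers this change, so the expectation is loose. A modest move toward stronger inhibition is expected, and a reading that again reports only a limit would be no surprise. The expected step is an at least 2.5-fold lower number from compound 1 to compound 3 (0.39 log units; beyond the scatter). For compound 3 the estimated value is 12000 nM, with an expected range from 3000 nM to 30000 nM.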

Compound 3, half-maximal inhibitory concentration: 14700 nM
Estimate against measurement, compound 3: 1.2-fold (0.09 log units) below, and the stated range covers the measured number.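

Among the compounds shown here, on an oxygen on an aromatic ring, 1-((dimethylamino)methyl)ethyl in place of benzyl yields the first actual number in this assay, with compound 3 at 14700 nM. The starting point is only a limit. The change reads as an at least 2.0-fold lower number from compound 1 to compound 3 (0.30 log units; that floor lies within the scatter), which fixes a floor for the step and leaves its true size unknown. This oxygen substituent is therefore the one change shown that brings a reading inside the range of the assay, while compound 1 and compound 2 each remain at a limit: the limit of > 30000 nM in this assay, at which 2 of the 3 values shown sit.

The compounds shown leave open whether the dimethylamino nitrogen or the loss of the benzyl ring accounts for the number. A chain without the branching methyl, a longer chain, or a cyclic amine such as morpholine or pyrrolidine on the same oxygen would begin to separate these.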